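Swapping the nitrile of compound 3 for a dimethylamide

The compounds below may be only part of what the source reports. "The series", "measured", "known", "first", "only" and "open" are said of these compounds alone.

Measured so far:
compound 1 `COc1ccc2c(c1)OC(c1cc(OC)c(OC)c(OC)c1)C(C(=O)NC(C)(C)C)=C2` — 28400 nM
compound 2 `COc1ccc2c(c1)OC(c1cc(OC)c(OC)c(OC)c1)C(C(=O)OC(C)(C)C)=C2` — 14100 nM
compound 3 `COc1ccc2c(c1)OC(c1cc(OC)c(OC)c(OC)c1)C(C#N)=C2` — 3400 nM

All three were tested in a functional assay for inhibition of nuclear factor NF-kappa-B complex (Homo sapiens); a lower number here means a stronger inhibitor, a higher number a weaker inhibitor. Compound 3 stands lowest of the three, and its gaps to compound 2 and compound 1 both lie beyond the scatter. Compound 4 `COc1ccc2c(c1)OC(c1cc(OC)c(OC)c(OC)c1)C(C(=O)N(C)C)=C2` has not been measured; it differs from compound 3 by dimethylcarbamoyl in place of cyano on a double-bonded ring carbon. Going by the values given here, two measured steps bear on this change: an 8.4-fold lower number from compound 1 to compound 3 (0.92 log units; beyond the scatter) and a 4.1-fold lower number from compound 2 to compound 3 (0.62 log units; beyond the scatter). In both, the cyano compound gives the lower number than the compound bearing a carbonyl group. Going back from cyano to a carbonyl-bearing group is therefore expected to raise the number, by about a 4.1-fold higher number from compound 3 to compound 4 (0.61 log units; beyond the scatter). Compound 4 is expected to give 14000 nM, within a range of 5000 nM to 40000 nM.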

Compound 4, half-maximal inhibitory concentration: > 50000 nM
Compound 4: no number, only a limit; the forecaster's own chance of this, stated with the estimate: 10%; middle value at least 3.5-fold (0.55 log units) from the limit.
By their numbers in this assay, from the lowest: compound 3; then compounds 2 and 1 (each within the scatter of the next). At a limit, above all of these: compound 4.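

Compound 4 gives only a limit of the assay, not a number: the limit of > 50000 nM in this assay, at which 1 of the 4 values shown sits. On this double-bonded ring carbon, replacing the nitrile with dimethylcarbamoyl costs more than the earlier carbonyl compounds showed, with an at least 14-fold higher number from compound 3 to compound 4 (1.16 log units; beyond the scatter) and an at least 3.5-fold higher number from compound 2 to compound 4 (0.54 log units; beyond the scatter). The two amides cannot be ordered, with an at least 1.7-fold higher number from compound 1 to compound 4 (0.24 log units; that floor lies within the scatter).

Still open, as far as these compounds go, is whether a primary amide or a carboxylic acid on this carbon would stay close to compound 3. Also open, from the compounds shown here alone, is whether any group here would give a lower number than the nitrile.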